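The source may hold more compounds than are shown below. What is called first, only, known or untested is meant among the compounds shown, and "the series" means these compounds.

Measured compounds in a functional assay on A549 cells (Homo sapiens) for antiproliferative activity, read by MTT assay, with a stated time of 48 h; a higher number here means a weaker inhibitor, a lower number a stronger inhibitor:
- compound 1 `N#Cc1ncn(-c2ccc(F)cc2)c1/N=C/c1ccc([N+](=O)[O-])cc1`: 18100 nM
- compound 2 `CC(C)c1ccc(/C=N/c2c(C#N)ncn2-c2ccc(F)cc2)cc1`: 14700 nM

Among the measured compounds shown here, compound 1 carries the higher of the two numbers, but the only measured step, a 1.2-fold lower number from compound 1 to compound 2 (0.09 log units; within the scatter), is inside the scatter, so compound 1 and compound 2 are not separated by this assay; both sit at weak activity.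

The next compound, compound 3 `N#Cc1ncn(Cc2ccc(F)cc2)c1/N=C/c1ccc([N+](=O)[O-])cc1`, is the unmeasured partner of compound 1. The change is 4-fluorobenzyl in place of 4-fluorophenyl on an aromatic nitrogen. For the measured compounds named here, nothing measured so far touches the aromatic nitrogen of the shared core: the one step available, a 1.2-fold lower number from compound 1 to compound 2 (0.09 log units; within the scatter), alters the substituent on the far aryl ring of the imine and does not bear on the aryl-to-benzyl exchange at the ring nitrogen. Going by the values given here, no measured step therefore informs the direction of the change from compound 1 to compound 3, and the prior is that the number stays near the level of compound 1 and compound 2.

The expected step is a 1.0-fold lower number from compound 1 to compound 3 (0.00 log units; within the scatter), that is none beyond the scatter, with wide uncertainty. Compound 3 is estimated at 18000 nM in this assay, with a range of 5500 nM to 60000 nM.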

Compound 3, half-maximal inhibitory concentration: 2020 nM
The estimate for compound 3 lay 8.9-fold (0.95 log units) above the measured number; measured number outside the range, below it.
By their numbers in this assay, from the lowest: compound 3; then compounds 2 and 1 (each within the scatter of the next).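

In this assay, among the compounds shown here, the aromatic nitrogen of the shared core is a place where the number responds: a 9.0-fold lower number from compound 1 to compound 3 (0.95 log units; beyond the scatter) with 4-fluorobenzyl in place of 4-fluorophenyl, and this step lies beyond the scatter, whereas the only earlier step, a 1.2-fold lower number from compound 1 to compound 2 (0.09 log units; within the scatter) with isopropyl in place of nitro on the far aryl ring, stayed within it. The exchange keeps the fluorinated six-membered aromatic ring and only sets a methylene link on the nitrogen, with no hydrogen-bond donors or acceptors entering or leaving, so a small change at this place is enough to separate compound 3 from compound 1. No measurement at hand accounts for the size of this step.

Still open, going by these compounds, is whether the lower number persists with a longer link such as 2-(4-fluorophenyl)ethyl, with an unsubstituted benzyl group lacking the fluorine, or with a basic amine on the end of an alkyl chain at this nitrogen. Also open, on these data alone, is whether isopropyl in place of nitro stays as flat on the 4-fluorobenzyl series as it did on the 4-fluorophenyl pair.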